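The compounds below may be only part of what the source reports. "The series", "measured", "known", "first", "only" and "open" are said of these compounds alone.

Compound 2 `O=C(CN(c1ncnc2c1ncn2C1CCCCO1)C1CC1)N[C@@H](CO)C(=O)OCc1ccccc1` carries a hydroxymethyl on the saturated chain carbon bound to an amide-type nitrogen and a carbonyl carbon. In a functional assay on the whole organism (Tail, strain ICR) with Mus musculus as the target, in the tail flick test, with a stated time of 90 min, at a dose of 25 umol/kg by the oral route (on this read-out lower numbers stand for a weaker effect and higher numbers for a stronger effect at the one dose given), compound 2 gives 32.2%. Compound 3 `NCCCC[C@H](NC(=O)CN(c1nc(Cl)nc2[nH]cnc12)C1CC1)C(=O)OCc1ccccc1` gives 35.3%, which is within the scatter of compound 2. Compound 1 `N=C(N)NCCC[C@H](NC(=O)CN(c1ncnc2c1ncn2C1CCCCO1)C1CC1)C(=O)OCc1ccccc1` gives 61.6%, and the step of a number 29.4 percentage points lower from compound 1 to compound 2 (beyond the scatter) is the only one among these three that reaches beyond the scatter.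

Compound 4 `CC(C)[C@H](NC(=O)CN(c1ncnc2c1ncn2C1CCCCO1)C1CC1)C(=O)OCc1ccccc1` differs from compound 2 by isopropyl in place of hydroxymethyl on a saturated chain carbon bound to an amide-type nitrogen and a carbonyl carbon. Among the compounds with values here, the measured step that bears on this position is the one from compound 1 to compound 2, where a large group was exchanged for an oxygen atom and the read-out fell by a modest amount; here a hydroxymethyl is exchanged for an isopropyl, so that step guides the expectation only loosely. With compound 3 also near compound 2, the step of a number 2.8 percentage points higher from compound 2 to compound 4 (within the scatter) is expected to stay within the scatter. Compound 4 is therefore estimated at 35%, within a range from 15% to 58%.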

Compound 4, a percentage reported as activity, at one dose (the size of the read-out at that dose, not a potency): 30.1%
Compound 4: the middle estimate sits 4.9 percentage points above what was measured; low and high end bracket the measured number.
By their numbers in this assay, from the lowest: compounds 4, 2 and 3 (each within the scatter of the next); then compound 1.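

At the saturated chain carbon bound to an amide-type nitrogen and a carbonyl carbon, replacing hydroxymethyl with isopropyl, which has no hydrogen-bond donors or acceptors, gives a number 2.1 percentage points lower from compound 2 to compound 4 (within the scatter) in this assay, so this read-out does not separate the two groups. The group carried by compound 1 now stands apart from both smaller groups, since the exchange for isopropyl gives a number 31.5 percentage points lower from compound 1 to compound 4 (beyond the scatter), in line with the earlier step to hydroxymethyl. No measurement at hand explains this difference.

From the compounds shown here alone, how an amine or a carboxylic acid at this place would read remains open. So does whether a longer chain of carbon atoms alone, without the nitrogens, would reach the level of compound 1 on the same core.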